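A few compounds are considered here, and "the series" means these few. Any claim that something is new, unique, unknown or untested is made for them only; others in the source may bear on it.

Working notes on the benzamide series.

Compound 1 `O=C(Nc1ccc([N+](=O)[O-])cc1OCc1ccccc1)c1ccccc1` is the parent amide. In an assay on SK-BR-3 cells for inhibition of Aromatase (Homo sapiens) (a lower number here means a stronger inhibitor, a higher number a weaker inhibitor), compound 1 gives > 25000 nM, which is a limit of the assay and not a measured number. Compound 2 `O=C(Nc1ccc([N+](=O)[O-])cc1OCc1ccccc1)c1ccc(Cl)c([N+](=O)[O-])c1` carries 4-chloro-3-nitrophenyl in place of phenyl on the carbonyl carbon. In this assay compound 2 gives > 25000 nM, again a limit and not a number. The step that the two limits leave unreadable from compound 1 to compound 2 therefore cannot be read in size or direction. Where compound 2 stands is thus known only as a limit, and the one other value shown is a limit too; both sit at the limit of > 25000 nM in this assay, at which 2 of the 2 values shown sit.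

Compound 3 `O=C(Nc1ccc([N+](=O)[O-])cc1OCc1ccccc1)c1ccc2ccccc2c1` differs from compound 2 by naphthalen-2-yl in place of 4-chloro-3-nitrophenyl on a carbonyl carbon. Going by the values given here, no measured step bears on this change, since the only step recorded, from compound 1 to compound 2, is unreadable between two limits. The expectation for this assay is therefore no readable step, with compound 3 most likely returning a limit as well, so the estimated step of a number no higher from compound 2 to compound 3 (the limit leaves the size open) is taken as flat. The estimate for compound 3 is 25000 nM, with a range from 8000 nM to 100000 nM, and a high chance that only a limit is reported.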

Compound 3, half-maximal inhibitory concentration: > 25000 nM
Compound 3: no number, only a limit (the forecaster's own chance of this, stated with the estimate: 80%); the middle value sits exactly at the limit.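

In this assay compound 3 gives > 25000 nM, a limit of the assay and not a number. The steps among compound 1, compound 2 and compound 3 therefore cannot be read, in size or in direction: the limit of > 25000 nM in this assay, at which 3 of the 3 values shown sit. The compounds shown leave open whether any group on the carbonyl carbon of the shared core gives a measurable value in this assay.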